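A few compounds are considered here, and "the series" means these few. Any claim that something is new, unique, unknown or untested is made for them only; others in the source may bear on it.

Measured compounds and values so far:
- compound 1, `Cc1cc(Cl)cc2c1NC(c1cn[nH]c1)NC2=O`: "not determined" (no result reported)
- compound 2, `O=C1NC(c2c[nH]nc2-c2ccccc2)Nc2c(I)cc(Cl)cc21`: "not determined" (no result reported)
- compound 3, `Cc1cc(Cl)cc2c1NC(c1c[nH]nc1-c1cccc3ccccc13)NC2=O`: 4000 nM

Among the measured compounds shown here, in an assay on HEK293 cells for inhibition of transient receptor potential cation channel subfamily M member 2 (Homo sapiens), read by patch clamp, with a stated time of 60 s (on this read-out lower numbers stand for stronger inhibition and higher numbers for weaker inhibition), compound 3 gives 4000 nM and is the only compound of the series with a number on this read-out. For the measured compounds named here, for compound 1 this assay records "not determined" (no result reported), and for compound 2 this assay records "not determined" (no result reported), so no comparison between measured compounds can be drawn and nothing calibrates the size of any structural change.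

The next compound, compound 4 `Cc1cc(Br)cc2c1NC(c1c[nH]nc1-c1cccc3ccccc13)NC2=O`, differs from compound 3 only in one place: bromo in place of chloro on an aromatic carbon. The exchange keeps the heavy-atom count, the ring count and the donor and acceptor counts unchanged, and the rest of the core is the same.

Going by the values given here, with no measured step to lean on, the expectation for the step of a 1.1-fold lower number from compound 3 to compound 4 (0.06 log units; within the scatter) is that it stays within the usual scatter of this assay, in no firm direction. Compound 4 is therefore estimated at 3500 nM in this assay, within a range from 1500 nM to 9000 nM, to be confirmed once the measurement is in hand.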

Compound 4, half-maximal inhibitory concentration: 3700 nM
Estimate against measurement, compound 4: 1.1-fold (0.02 log units) below, within the range that was stated.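

In this assay, among the compounds shown here, the exchange of chloro for bromo on this aromatic carbon gives a 1.1-fold lower number from compound 3 to compound 4 (0.03 log units; within the scatter) and so yields the first readable step. At this position, meta to a methyl group, the two halogens cannot be told apart on this read-out, and the series now has one step against which later changes can be set. No available data explain this match.

On these data alone, it remains open whether a group of another kind here, such as a methoxy, an amine or a carboxylic acid, would move the number beyond the scatter in this assay. Also open, as far as these compounds go, is whether plain hydrogen at this position, or ethyl in place of the methyl group, would leave the number where it stands.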